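Glycinamide N-methylation across two cores in HeLa

The compounds below may be only part of what the source reports. "The series", "measured", "known", "first", "only" and "open" are said of these compounds alone.

Compound 1 `COc1ccc(C(=O)c2ccc(OC)c3c2C=CC(C)(C)O3)c(NC(=O)CN)c1` and compound 3 `C=C(c1ccc2c(c1)C=CC(C)(C)O2)c1ccc(OC)cc1NC(=O)CN` share the methoxyphenyl glycinamide portion but sit on different cores; the difference between the two cores is not broken down here. In a functional assay on HeLa cells (Homo sapiens) for antiproliferative activity, read by MTT assay, with a stated time of 48 h (on this read-out lower numbers stand for stronger inhibition and higher numbers for weaker inhibition), compound 1 gives 100 nM, and compound 3 gives 160 nM; the two values lie within the usual scatter of each other, so no order between them is claimed.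

Compound 2 `CNCC(=O)Nc1cc(OC)ccc1C(=O)c1ccc(OC)c2c1C=CC(C)(C)O2` is compound 1 carrying the change (methyl in place of hydrogen on an amine nitrogen). This change gave a 22-fold higher number from compound 1 to compound 2 (1.34 log units; beyond the scatter), a clear loss of antiproliferative activity on the core of compound 1. In this assay compound 2 gives 2170 nM.

Compound 4 `C=C(c1ccc2c(c1)C=CC(C)(C)O2)c1ccc(OC)cc1NC(=O)CNC` is compound 3 carrying the change (methyl in place of hydrogen on an amine nitrogen). The change is the same as that from compound 1 to compound 2: the group that leaves, the group that enters and the place are described in identical words for both pairs. Among the measured compounds shown here, the only difference between the two pairs is the core, and the two cores are not compared in any counted way here, so the single measured step is the sole guide.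

Compound 4 is therefore expected to lose activity in this assay by about a 16-fold higher number from compound 3 to compound 4 (1.19 log units; beyond the scatter), resting on the step from compound 1 to compound 2 a 22-fold higher number from compound 1 to compound 2 (1.34 log units; beyond the scatter) applied to compound 3 160 nM. For the measured compounds named here, for compound 4 the estimate in this assay is 2500 nM, with a range from 700 nM to 9000 nM, the width reflecting that the change has been measured on only one core.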

Compound 4, half-maximal inhibitory concentration: 410 nM
The estimate for compound 4 lay 6.1-fold (0.79 log units) above the measured number, outside the stated range (below it).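

In this assay, methyl in place of hydrogen on the amine nitrogen also costs activity on the core of compound 3, giving a 2.6-fold higher number from compound 3 to compound 4 (0.41 log units; beyond the scatter), so the direction of the change holds on both cores shown. Its size does not carry over, and the change cannot be treated as a fixed increment between these two cores: the same change on two cores in this assay, a 22-fold higher number (1.34 log units; beyond the scatter) from compound 1 to compound 2 and a 2.6-fold higher number (0.41 log units; beyond the scatter) from compound 3 to compound 4, 8.5-fold (0.93 log units) apart, beyond the scatter of two such steps

These notes show that the core alters how much this change costs, but they rest on a single pair for each core, and they do not show which difference between the cores accounts for the gap, or whether a further core would sit near either step.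

The compounds shown leave open how the amine responds to larger or fuller substitution, such as ethyl on the same nitrogen or a dimethylamino end, and whether either core would tolerate these better than methylamino. They also leave open whether a longer chain between the amide carbonyl and the amine would keep the two cores apart in the same way in this assay.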